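The source may report more compounds than this note shows. Statements on the series, on what has been measured and on what is new or still open speak of the compounds shown alone.

Measured so far:
Compound 1 `O=C(CCc1cn(Cc2ccc3oc(-c4ccccc4)cc(=O)c3c2)nn1)Nc1ccc(Cl)cc1` — 15600 nM
Compound 2 `O=C(CCc1cn(Cc2ccc3oc(-c4ccc(Cl)cc4)cc(=O)c3c2)nn1)Nc1ccccc1` — 32900 nM
Compound 3 `Cc1ccc(NC(=O)CCc2cn(Cc3ccc4oc(-c5ccc(Cl)cc5)cc(=O)c4c3)nn2)cc1` — 32900 nM

All three were run in an assay on isolated protein for inhibition of Amine oxidase [flavin-containing] B (Homo sapiens), read by fluorescence and spectrophotometry; a lower number here means a stronger inhibitor, a higher number a weaker inhibitor. Compound 3 stands level with compound 2 at the digits printed, the two of them together the highest numbers of the set; compound 1 gives the lowest number, a step from compound 3 that lies beyond the scatter. Compound 1 differs from the other two in two places at once, so nothing can be read off as a single step from it.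

The next compound is compound 4 `O=C(CCc1cn(Cc2ccc3oc(-c4ccc(Cl)cc4)cc(=O)c3c2)nn1)Nc1ccc(Cl)cc1`. The change from compound 3 is chloro in place of methyl on an aromatic carbon. Among the compounds with values here, the one measured step at the same place is no change at the digits printed from compound 2 to compound 3 (within the scatter), where methyl in place of hydrogen on an aromatic carbon left the number unchanged within the scatter. Within the data shown here, that is the only evidence bearing on the amide-side ring, and it points to small sensitivity there. Chloro in place of methyl is therefore expected to give a 1.1-fold lower number from compound 3 to compound 4 (0.04 log units; within the scatter), nothing beyond the scatter.

Compound 4 is estimated at 30000 nM, with a range of 12000 nM to 75000 nM.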

Compound 4, half-maximal inhibitory concentration: 32900 nM
Compound 4: middle estimate off by 1.1-fold (0.04 log units), on the low side; measured number inside the range.
By their numbers in this assay, from the lowest: compound 1; then compounds 2, 3 and 4 (each within the scatter of the next).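

At this place on the amide-side ring, chloro now reads the same as methyl, with no change at the digits printed from compound 3 to compound 4 (within the scatter), and the same as hydrogen, with no change at the digits printed from compound 2 to compound 4 (within the scatter), so in this assay the three groups cannot be told apart while the 4-chlorophenyl on the core stays fixed. Within the data shown here, the only step beyond the scatter lies on the other ring, where keeping the amide-side 4-chlorophenyl and placing chloro in place of hydrogen on the core's ring gives a 2.1-fold higher number from compound 1 to compound 4 (0.32 log units; beyond the scatter), a modest step. Nothing available accounts for either the flat amide-side readings or this step on the other ring.

On these data alone, whether the amide-side ring stays this flat with an amine or a carboxylic acid at the same place remains open. Also open, as far as these compounds go, is whether the step on the core's ring holds with hydrogen on the amide-side ring, or with a longer chain leading to the amide.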